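Swapping phenyl for 2,4-difluorophenyl on a fatty acid receptor agonist

The source may report more compounds than this note shows. Statements on the series, on what has been measured and on what is new or still open speak of the compounds shown alone.

Of the compounds shown here, two have been measured in an assay on isolated protein for agonist activity at Free fatty acid receptor 1 (Homo sapiens); a lower number here means that less compound is needed, a higher number that more compound is needed for the effect. Compound 1 `CC#CC(CC(=O)O)c1ccc(OCc2ccn3cc(-c4ccccc4)nc3c2)cc1` gives 1260 nM in this assay. Compound 2 `CC#CC(CC(=O)O)c1ccc(OCc2ccc3nc(-c4ccccc4)cn3c2)cc1`, which carries the same phenyl group on a differently arranged fused core, gives 979 nM in this assay. The two numbers lie within the usual scatter of each other, so nothing separates compound 1 from compound 2 on the evidence at hand.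

Compound 3 `CC#CC(CC(=O)O)c1ccc(OCc2ccn3cc(-c4ccc(F)cc4F)nc3c2)cc1` has not yet been measured. It differs from compound 1 in one place: 2,4-difluorophenyl in place of phenyl on an aromatic carbon. Two fluorine atoms are added to the ring that hangs from the five-membered aromatic ring of the fused core; the acid chain and the rest of the molecule are unchanged.

Among the measured compounds shown here, no measured pair shows what such a change does here, so the expectation rests on compound 1 alone. The step from compound 1 to compound 3 is expected to be small, most likely no larger than the scatter, as a 1.4-fold lower number from compound 1 to compound 3 (0.15 log units; within the scatter). Compound 3 is therefore estimated at 900 nM in this assay, with a plausible range from 300 nM to 2700 nM.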

Compound 3, half-maximal effective concentration: 792 nM
Beside the measured number, compound 3's estimate is 1.1-fold (0.06 log units) above it, and the stated range covers the measured number.
By their numbers in this assay, from the lowest: compounds 3, 2 and 1 (each within the scatter of the next).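

In this assay, among the compounds shown here, placing 2,4-difluorophenyl on this aromatic carbon of the five-membered ring gives a 1.6-fold lower number from compound 1 to compound 3 (0.20 log units; within the scatter), so this is the first direct comparison at this position, and it shows that the two added fluorine atoms leave the number within the normal spread of repeat measurements. The position therefore accepts a ring with two more heavy atoms than phenyl, with no change in this assay that can be told apart from scatter. Nothing else measured here bears on why the result came out this way.

The compounds shown leave open whether a single fluorine atom, a chlorine atom or a methoxy group on the same ring would move the number beyond the scatter, and whether replacing the ring with an amine or a cyclohexyl group would do so. They also leave open whether 2,4-difluorophenyl in place of phenyl on the differently arranged core of compound 2 would likewise stay within the scatter.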